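The source may hold more compounds than are shown below. What is called first, only, known or untested is meant among the compounds shown, and "the series" means these compounds.

Measured so far:
Compound 1, `CNC(=O)[C@]12C[C@@H]1[C@@H](n1cnc3c(NCc4cccc(Cl)c4)nc(C#Cc4ccccc4)nc31)[C@H](O)[C@@H]2O`: >= 99 nM
Compound 2, `CNC(=O)[C@]12C[C@@H]1[C@@H](n1cnc3c(NCc4cccc(Cl)c4)nc(C#Cc4ccc(F)cc4)nc31)[C@H](O)[C@@H]2O`: >= 99 nM

Both compounds share one core and differ only in the group at the end of the triple bond. In an assay on isolated protein for binding affinity to adenosine receptor A3 (Homo sapiens) (on this read-out lower numbers stand for stronger inhibition and higher numbers for weaker inhibition), compound 1 gives >= 99 nM, which is a limit of the assay and not a measured number. Compound 2 likewise gives >= 99 nM in this assay, again a limit rather than a number. The step that the two limits leave unreadable from compound 1 to compound 2 therefore cannot be sized, because of the limit of >= 99 nM in this assay, at which 2 of the 2 values shown sit. All that the two measurements show is that neither compound reached the region where a number is reported.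

Compound 3, `CNC(=O)[C@]12C[C@@H]1[C@@H](n1cnc3c(NCc4cccc(Cl)c4)nc(C#Cc4ccc(Cl)s4)nc31)[C@H](O)[C@@H]2O`, has not yet been measured. It differs from compound 2 by 5-chlorothiophen-2-yl in place of 4-fluorophenyl on a triple-bonded carbon. For the measured compounds named here, no readable step bears on this change: the only step, from compound 1 to compound 2, is hidden by the limit. The expectation therefore rests on the two limits alone, and the most likely outcome is another limit. Compound 3 is estimated at 400 nM in this assay, with a range from 100 nM to 3000 nM. The estimated step that the limit leaves unreadable from compound 2 to compound 3 is expected to be small, no larger than the scatter.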

Compound 3, inhibition constant: >= 99 nM
Compound 3: a limit, no number (the forecaster's own chance of this, stated with the estimate: 75%); the middle value is on the limit's open side.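

In this assay compound 3 again gives only a limit of the assay, so its steps from compound 1 and from compound 2 cannot be read, because all three compounds sit at the same limit: the limit of >= 99 nM in this assay, at which 3 of the 3 values shown sit. The compounds shown leave open what the true affinity of each compound is, and whether changing the group on the triple bond alters it at all.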